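The source may report more compounds than this note shows. Statements on the series, on what has been measured and on what is new or still open speak of the compounds shown alone.

Working notes on the series. Three compounds sharing one core have been run in an ADME assay on liver for metabolic stability, with Liver microsome (Homo sapiens) as the target, read by LC-MS, using microsomes and NADPH, with a stated time of 30 min, tested at 1 uM; a lower number here means that less of the compound is left, a higher number that more of the compound is left. Compound 1 `Cc1cc(CCC#N)cc(C)c1Oc1cc(Nc2ccc(C#N)cc2)c(N)cc1C(=O)N(C)C` gives 72.2%. Compound 2 `CCNC(=O)c1cc(N)c(Nc2ccc(C#N)cc2)cc1Oc1c(C)cc(CCC#N)cc1C` gives 85.2%. Compound 3 `Cc1cc(CCC#N)cc(C)c1Oc1cc(Nc2ccc(C#N)cc2)c(N)cc1C(=O)NC1CC1` gives 63.2%. Every measured step among them alters only the group on the amide-type nitrogen: a number 13 percentage points higher from compound 1 to compound 2 (beyond the scatter); a number 9 percentage points lower from compound 1 to compound 3 (within the scatter); a number 22 percentage points lower from compound 2 to compound 3 (beyond the scatter). Compound 3 therefore stands lowest of the three numbers, with compound 1 within the scatter of it and compound 2 beyond it.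

Compound 4 `Cc1cc(CCC#N)cc(C)c1Oc1cc(Nc2ccc(C#N)cc2)c(N)cc1CN(C)C` has not yet been run in this assay. It differs from compound 3 as follows: (dimethylamino)methyl in place of cyclopropylcarbamoyl on an aromatic carbon. None of the three measured steps bears directly on this change, since each of them kept the carbonyl and the amide-type nitrogen in place and varied only what sits on that nitrogen, whereas here the whole cyclopropylcarbamoyl group leaves and (dimethylamino)methyl enters. The measured steps at this position ranged from within the scatter to modest, but they give no reading on a change of this kind, so no direction can be taken from the data and the range must be kept wide. Compound 4 is expected at 55%, between 30% and 80%. The expected step is a number 8.2 percentage points lower from compound 3 to compound 4 (within the scatter).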

Compound 4, percent of the compound remaining: 93.3%
The estimate for compound 4 lay 38.3 percentage points below the measured number; measured number above the stated range.
By their numbers in this assay, from the lowest: compounds 3 and 1 (each within the scatter of the next); then compounds 2 and 4 (each within the scatter of the next).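

The earlier compounds shown here varied only what sits on the amide-type nitrogen, whereas this change removes the carbonyl altogether and puts (dimethylamino)methyl on the aromatic carbon para to the (4-cyanophenyl)amino group, and in this assay the outcome depends on which amide it replaces: a number 30.1 percentage points higher from compound 3 to compound 4 (beyond the scatter) for cyclopropylcarbamoyl, a number 21.1 percentage points higher from compound 1 to compound 4 (beyond the scatter) for dimethylcarbamoyl, and a number 8.1 percentage points higher from compound 2 to compound 4 (within the scatter) for ethylcarbamoyl. An amide carbonyl at this position is therefore not required for a read-out on a par with the best amide here, compound 2, although compound 4 cannot be placed in any order relative to it. Nothing available here accounts for these numbers.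

The compounds shown leave open whether the result belongs to the dimethylamino group or to the methylene carbon that now joins it to the ring, a question that aminomethyl, (methylamino)methyl or (cyclopropylamino)methyl on the same aromatic carbon would address. They also leave open how a longer chain, such as 2-(dimethylamino)ethyl, or a carboxylic acid at this position would read in this assay.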